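Replacing pyridin-3-yl with 4-cyanophenyl on the ring amine

The source may report more compounds than this note shows. Statements on the series, on what has been measured and on what is new or still open speak of the compounds shown alone.

Compound 1 `Nc1ccccc1NC(=O)c1ccc(CSC(=S)N2CCc3ccccc32)cc1` gives 85.4% in a functional assay on A-375 cells (Homo sapiens) for antiproliferative activity, read by CCK-8 assay, with a stated time of 72 h, tested at 8 uM; a lower number here means a weaker effect, a higher number a stronger effect of the compound at the concentration tested.
Compound 2 `Nc1ccccc1NC(=O)c1ccc(CSC(=S)N2CCN(c3cccnc3)CC2)cc1` gives 88.8% in this assay.
Compound 3 `Nc1ccccc1NC(=O)c1ccc(CSC(=S)N2CCc3cc(Cl)ccc32)cc1` gives 82.3% in this assay.

The three measured compounds share a core and differ only in the group carried on the thiocarbamate nitrogen. Compound 2 shows the highest of the three numbers, but its gap to compound 1 and to compound 3 is within the scatter, so the three cannot be ranked.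

Compound 4 `N#Cc1ccc(N2CCN(C(=S)SCc3ccc(C(=O)Nc4ccccc4N)cc3)CC2)cc1` is not yet measured. It differs from compound 2 in one place: 4-cyanophenyl in place of pyridin-3-yl on an amine nitrogen in a ring. For the measured compounds named here, no measured step involves this part of the molecule. Going by the values given here, the only measured step, a number 3.1 percentage points lower from compound 1 to compound 3 (within the scatter), concerns a chloro on an aromatic carbon elsewhere and stays within the scatter, so it gives no direct guide, only a hint that small aromatic changes here have not moved the read-out much.

Because compound 2 gives 88.8% and no step beyond the scatter is known, compound 4 is expected to give 85%, between 72% and 95%. That corresponds to an expected step of a number 3.8 percentage points lower from compound 2 to compound 4 (within the scatter), which is not beyond the scatter.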

Compound 4, a percentage reported as inhibition, at one concentration (the size of the read-out at that concentration, not a potency): 62.9%
Compound 4: middle estimate off by 22.1 percentage points, on the high side, and the stated range ends above it.
By their numbers in this assay, from the lowest: compound 4; then compounds 3, 1 and 2 (each within the scatter of the next).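

Within this assay, replacing pyridin-3-yl with 4-cyanophenyl on the amine nitrogen in the ring gives a number 25.9 percentage points lower from compound 2 to compound 4 (beyond the scatter). For the compounds shown here, this is the first step to lie beyond the scatter, so this position can move the read-out in a way that the closely grouped earlier compounds could not reveal. The data shown offer no measured explanation for this step.

From the compounds shown here alone, the change swaps a ring nitrogen for carbon and also adds a nitrile, so it remains open which of the two goes with the lower number; a plain phenyl group on the same nitrogen would separate them. Going by these compounds, it is also open whether an amine or a carboxylic acid in place of the nitrile would give a similar number.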